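Cytotoxicity notes on a benzylimidazole series, compound 3 to 4

The source may hold more compounds than are shown below. What is called first, only, known or untested is meant among the compounds shown, and "the series" means these compounds.

Measured compounds:
- compound 1, `COC(=O)c1ccc(NCc2cncn2Cc2ccc(N)cc2)cc1-c1ccccc1`, in a toxicity assay on NIH3T3 cells (Mus musculus) for cytotoxicity, read by resazurin assay (a higher number here means that more compound is needed for the effect, a lower number that less compound is needed), compound 1 gives > 10000 nM, which is a limit of the assay and not a number.
- compound 2, `COC(=O)c1ccc(NCc2cncn2Cc2ccc(-c3ccccc3)cc2)cc1-c1ccccc1`, in this assay compound 2 gives > 1000 nM, again a limit rather than a number.
- compound 3, `COC(=O)c1ccc(NCc2cncn2Cc2ccc(F)cc2)cc1-c1ccccc1`, in this assay compound 3 gives "not determined" (no result reported).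

Among the measured compounds shown here, compound 3 therefore has no number of its own in this assay; the only values are the two limits, the limit of > 1000 nM in this assay, at which 1 of the 3 values shown sits, and (the limit of > 10000 nM in this assay, at which 1 of the 3 values shown sits). The step that the two limits leave unreadable from compound 1 to compound 2 cannot be read because both ends sit at a limit.

The next compound is compound 4, `COC(=O)c1ccc(NCc2cncn2Cc2ccc(C#N)cc2)cc1-c1ccccc1`. The change from compound 3 is cyano in place of fluoro on an aromatic carbon; the 4-fluorobenzyl becomes a 4-cyanobenzyl. For the measured compounds named here, no measured step in this assay bears on this change, and compound 3 itself has no value, so nothing points to a direction or size of step. All that is known is that the measured relatives sit at limits. Compound 4 is expected to give about 10000 nM in this assay, estimated between 2000 nM and 50000 nM, most likely reported only as a limit.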

Compound 4, half-maximal effective concentration: > 10000 nM
Compound 4 ended at the assay's limit; the forecaster's own chance of this, stated with the estimate: 80%; the middle value sits exactly at the limit.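

The steps from compound 1 to compound 4 and from compound 2 to compound 4 cannot be read, as all three values are limits of the assay and not numbers. Going by these compounds, whether compound 1, compound 2 and compound 4 truly differ in this assay, and where compound 3 stands, remains open.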